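Compound 3 against a limit in microsomal clearance

This account rests on a few compounds, and the source may have more. Where it says the series, first, only, none or still open, it means among the compounds named here.

Measured in an in vitro ADME assay on microsomes from liver (Rattus norvegicus) for metabolic stability; a higher number here means faster removal of the compound, a lower number slower removal:
- compound 1 `Nc1ccnc(Nc2ccc(Oc3ccc(Cl)cc3)cc2)c1`: > 399 mL.min-1.g-1, a limit
- compound 2 `Nc1cc(Nc2ccc(Oc3ccc(Cl)cc3)cc2)cnn1`: > 399 mL.min-1.g-1, a limit

Compound 2 has no exact number on this scale, and its reading of > 399 mL.min-1.g-1 is a limit of the assay. The same is true of the other measured compound, and the evidence so far amounts to the limit of > 399 mL.min-1.g-1 in this assay, at which 2 of the 2 values shown sit.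

Compound 3 `Nc1nsc(Nc2ccc(Oc3ccc(Cl)cc3)cc2)n1` follows from compound 2 through a single change, 3-amino-1,2,4-thiadiazol-5-yl in place of 6-aminopyridazin-4-yl on a nitrogen on an aromatic ring. Within the data shown here, the only measured step that bears on it also exchanged the group at this place, and it is a step that the two limits leave unreadable from compound 1 to compound 2. That step offers no size to carry over, so no shift beyond the scatter is expected in this assay, in either direction. The expected change is a step that the limit leaves unreadable from compound 2 to compound 3. Another limit reading would be no surprise. For compound 3 the estimate is 400 mL.min-1.g-1, with an expected range of 150 mL.min-1.g-1 to 900 mL.min-1.g-1.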

Compound 3, intrinsic clearance in microsomes: < 14 mL.min-1.g-1
Compound 3: only a limit was reported (the forecaster's own chance of this, stated with the estimate: 55%); middle value at least 28-fold (1.45 log units) from the limit.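

In this assay, the group on a nitrogen on an aromatic ring now proves able to move the read-out: 3-amino-1,2,4-thiadiazol-5-yl in place of 6-aminopyridazin-4-yl gives an at least 28-fold lower number from compound 2 to compound 3 (1.45 log units; beyond the scatter), and 3-amino-1,2,4-thiadiazol-5-yl in place of 4-aminopyridin-2-yl gives an at least 28-fold lower number from compound 1 to compound 3 (1.45 log units; beyond the scatter). From the compounds shown here alone, compound 3 gives < 14 mL.min-1.g-1, which is a limit and not a number, so these steps fix only a smallest size and their full extent stays unknown. The step between the two earlier compounds cannot be read, so this place shows a size for the first time, and the three compounds now sit at two opposite limits: the limit of < 14 mL.min-1.g-1 in this assay, at which 1 of the 3 values shown sits.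

The five-membered ring, its sulfur and its hetero atoms all enter together, so the compounds shown do not tell which of these features goes with the step. Going by these compounds, it also remains open whether the amine on the new ring matters, a question that a 1,2,4-thiadiazol-5-yl group carrying a methyl group in place of that amine would address.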